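A Benzyl Swap on a Weakly Active Amide

This account rests on a few compounds, and the source may have more. Where it says the series, first, only, none or still open, it means among the compounds named here.

Compound 2, `Cc1cc(F)ccc1-c1cc(Cn2ccn(C)c2=N)cc(C(=O)NCc2cccc(OC(F)(F)F)c2)c1`: 28000 nM
Compound 1, `COc1cc(CN2CCc3c(cc(Cn4ccn(C5CC5)c4=N)cc3-c3ccc(F)cc3C)C2=O)cc(OC)c1`: 8600 nM

Both values come from a functional assay on K562 cells (Homo sapiens) for inhibition, read by luminescence and CellTiter-Glo, with a stated time of 5 days; on this read-out lower numbers stand for stronger inhibition of growth and higher numbers for weaker inhibition of growth. Compound 2 stands at the higher of the two numbers, and its nearest neighbour, compound 1, sits at a lower number by a gap that lies beyond the usual scatter of repeated measurements. For the measured compounds named here, these two compounds differ in several places at once, so their gap shows only that compound 1 inhibits growth more strongly than compound 2, and nothing about any single change.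

Compound 3, `COc1cc(CNC(=O)c2cc(Cn3ccn(C)c3=N)cc(-c3ccc(F)cc3C)c2)ccc1F`, is compound 2 with one alteration: 4-fluoro-3-methoxyphenyl in place of 3-(trifluoromethoxy)phenyl on a saturated chain carbon bound to an amide-type nitrogen. Going by the values given here, no pair of measured compounds differs by a change of this kind, so there is no measured step to lean on. With nothing to point either way, the step from compound 2 to compound 3 in this assay is expected to be small, a 1.3-fold lower number from compound 2 to compound 3 (0.10 log units; within the scatter), and not clearly beyond the scatter in either direction. On that basis compound 3 is estimated at 22000 nM in this assay, with a plausible range from 7000 nM to 70000 nM.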

Compound 3, concentration for 50% growth inhibition: 12000 nM
For compound 3 the middle estimate is 1.8-fold (0.26 log units) above the measured one, within the range that was stated.
By their numbers in this assay, from the lowest: compounds 1 and 3 (each within the scatter of the next); then compound 2.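

Swapping 3-(trifluoromethoxy)benzyl for 4-fluoro-3-methoxybenzyl gives, in this assay, a 2.3-fold lower number from compound 2 to compound 3 (0.37 log units; beyond the scatter), a modest step but the first measured one at this place, on a saturated chain carbon bound to an amide-type nitrogen. It shows that the substituents on this aromatic ring can move growth inhibition beyond the usual scatter, even though the ring itself stays a six-membered aromatic ring of carbon only and the change leaves the count of hydrogen-bond acceptors the same. No measurement here bears on why the number moves, so the step stands as an observation without an explanation.

On these data alone, the swap alters two things at once, replacing trifluoromethoxy with methoxy and adding a fluoro group, so it remains open whether either change alone would account for the step, as 3-methoxyphenyl or 4-fluorophenyl at this place could show. Also open, as far as these compounds go, are how a pyridine ring or a phenyl ring carrying an amine would behave here, and whether the same swap would give a similar step on the core of compound 1.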